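Inducible nitric oxide synthase binding: amidine series notes

A few compounds are considered here, and "the series" means these few. Any claim that something is new, unique, unknown or untested is made for them only; others in the source may bear on it.

Measured so far:
compound 1, `N=C(NCCC[C@H](N)C(=O)O)NCCC(N)=O`, 30% in an assay on isolated protein for inhibition of Nitric oxide synthase, inducible (Homo sapiens), tested at 1 uM; on this read-out higher numbers stand for a weaker effect at the one concentration tested and lower numbers for a stronger effect;
compound 2, `C=CCC(=N)NCCC[C@H](N)C(=O)O`, 100% in this assay.

Compound 2 holds the highest of the two numbers in this assay, with compound 1 standing a long way below it, a gap beyond the scatter. Compound 3, `C/C=C/CC(=N)NCCC[C@H](N)C(=O)O`, is not yet measured. Its change from compound 2 is prop-1-en-1-yl in place of vinyl on a saturated chain carbon bound to a carbon with a double bond to nitrogen. Among the compounds with values here, no step between measured compounds involves this kind of change, so the expectation rests on compound 2 alone: a modest step is expected, a number 15 percentage points lower from compound 2 to compound 3 (beyond the scatter), and compound 3 is estimated at 85%, within 50% to 100%.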

Compound 3, a percentage reported as inhibition, at one concentration (the size of the read-out at that concentration, not a potency): 21%
For compound 3 the middle estimate is 64 percentage points above the measured one; the measured number lies below the stated range.
By their numbers in this assay, from the lowest: compounds 3 and 1 (each within the scatter of the next); then compound 2.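

In this assay the place on a saturated chain carbon bound to a carbon with a double bond to nitrogen proves sensitive: prop-1-en-1-yl in place of vinyl gives a number 79 percentage points lower from compound 2 to compound 3 (beyond the scatter), although the double bond count and the hydrogen-bond donor and acceptor counts of the group stay the same. No measurement at hand accounts for a step of this size.

This single pair is all that speaks for the place. Going by these compounds, whether a saturated propyl group, a cyclopropyl group or a longer alkenyl chain there would give a similar number remains open.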